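Cyano in place of hydrogen on the benzamide of compound 1

This account rests on a few compounds, and the source may have more. Where it says the series, first, only, none or still open, it means among the compounds named here.

Compound 1 `O=C(NCN1CCC(c2cccc[n+]2[O-])CC1)c1ccccc1` was tested in a functional assay on HEK293 cells for agonist activity at D(4) dopamine receptor (Homo sapiens), read by FLIPR (a lower number here means that less compound is needed, a higher number that more compound is needed for the effect), and there compound 1 gives 532 nM. Within the data shown here, of the three compounds measured so far, this is the highest number. Compound 2 `Cc1cccc(C(=O)NCN2CCC(c3nccs3)CC2)c1` gives 9.8 nM in this assay, and compound 3 `Cc1cccc(NC(=O)CN2CCC(c3cccc(O)c3)CC2)c1` gives 8 nM. Both of these lie far below compound 1, beyond the usual scatter, but each of them differs from compound 1 in more than one place, so no single change can be read from them.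

Compound 4 `N#Cc1cccc(C(=O)NCN2CCC(c3cccc[n+]3[O-])CC2)c1` keeps the whole of compound 1 except for one change: cyano in place of hydrogen on an aromatic carbon. Cyano in place of hydrogen on an aromatic carbon, meta to a large group. Among the measured compounds shown here, no pair of measured compounds shows this change on its own, so its effect must be estimated rather than read. Compounds 2 and 3 both carry a substituent on the corresponding aromatic ring and both give low numbers, while compound 1 carries none and gives the high number, which is the only hint available. On that basis the step from compound 1 to compound 4 is expected to be a modest lowering of the number, a 3.0-fold lower number from compound 1 to compound 4 (0.47 log units; beyond the scatter), though a result within the scatter would not be surprising. For compound 4 the expected value in this assay is estimated at 180 nM, with a likely range from 40 nM to 800 nM.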

Compound 4, half-maximal effective concentration: 840 nM
The estimate for compound 4 lay 4.7-fold (0.67 log units) below the measured number; the measured number lies above the stated range.
By their numbers in this assay, from the lowest: compounds 3 and 2 (each within the scatter of the next); then compounds 1 and 4 (each within the scatter of the next).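

In this assay, among these compounds, the pair gives the first direct reading of a single change: cyano in place of hydrogen on an aromatic carbon of the six-membered aromatic ring of carbon only, meta to a large group, gives a 1.6-fold higher number from compound 1 to compound 4 (0.20 log units; within the scatter). On the core of compound 1, then, this phenyl to 3-cyanophenyl change does not move the number beyond the usual scatter, so at this position cyano leaves the read-out indistinguishable from that with hydrogen. Nothing at hand gives a reason for this outcome.

This one step speaks only for cyano, at this one position and on this one core, so it cannot show whether a different group at the same place, such as an amine, a carboxylic acid or methoxy, would shift the number beyond the scatter. It also leaves open whether cyano at another carbon of the same ring, or on a different core, would give a similar result.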